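Triazole aryl swap on two related cores, cytotoxicity notes

A few compounds are considered here, and "the series" means these few. Any claim that something is new, unique, unknown or untested is made for them only; others in the source may bear on it.

Compound 1 `C=C1C[C@]23C[C@@]1(O)CC[C@H]2c1ccc(O)c(C)c1[C@@H]3Cn1cc(-c2ccccn2)nn1`, in a functional assay on A549 cells (Homo sapiens) for cytotoxicity, read by MTT assay, with a stated time of 4 days (a higher number here means a weaker inhibitor, a lower number a stronger inhibitor), a limit of the assay: > 20000 nM
Compound 2 `C=C1C[C@]23C[C@@]1(O)CC[C@H]2c1ccc(O)c(C)c1[C@@H]3Cn1cc(-c2ccc(C(F)(F)F)cc2)nn1`, in this assay: 10400 nM
Compound 3 `Cc1c(O)ccc2c1[C@H](Cn1cc(-c3ccccn3)nn1)[C@@]13CC(=O)[C@@](C)(CC[C@@H]21)C3`, in this assay a limit of the assay: > 20000 nM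

Compound 2 differs from compound 1 by 4-(trifluoromethyl)phenyl in place of pyridin-2-yl on an aromatic carbon. The measured step is an at least 1.9-fold lower number from compound 1 to compound 2 (0.28 log units; that floor lies within the scatter). Compound 3 has the same atoms as compound 1, joined differently; the difference between the two cores is not broken down here. Compound 4 `Cc1c(O)ccc2c1[C@H](Cn1cc(-c3ccc(C(F)(F)F)cc3)nn1)[C@@]13CC(=O)[C@@](C)(CC[C@@H]21)C3` is compound 3 with the same change, (4-(trifluoromethyl)phenyl in place of pyridin-2-yl on an aromatic carbon), the place being identical word for word in both pairs. Of note for the measured values: the limit of > 20000 nM in this assay, at which 2 of the 3 values shown sit.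

Since compound 3 sits at a limit, the starting point for compound 4 is only a floor. The step from compound 3 to compound 4 is expected to be an at least 1.4-fold lower number from compound 3 to compound 4 (0.15 log units; that floor lies within the scatter), resting on an at least 1.9-fold lower number from compound 1 to compound 2 (0.28 log units; that floor lies within the scatter). Compound 4 is therefore expected near 14000 nM, between 6000 nM and 40000 nM, with a real chance that the assay again reports only a limit.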

Compound 4, half-maximal inhibitory concentration: > 20000 nM
Compound 4: a limit, no number (the forecaster's own chance of this, stated with the estimate: 45%); at least 1.4-fold (0.15 log units) between middle value and limit.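

No step can be read between compound 3 and compound 4, because both results are limits of the assay: the limit of > 20000 nM in this assay, at which 3 of the 4 values shown sit.

As far as these compounds go, whether 4-(trifluoromethyl)phenyl in place of pyridin-2-yl shifts the number on the core of compound 3 stays open.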